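Compound 3 and a change of aromatic substituent

The source may hold more compounds than are shown below. What is called first, only, known or untested is meant among the compounds shown, and "the series" means these compounds.

In a functional assay on KBVIN cells (Homo sapiens) for antiproliferative activity, read by sulforhodamine B assay, with a stated time of 3 days (a lower number here means that less compound is needed, a higher number that more compound is needed for the effect), compound 1 (`CCCc1ccc(-c2cc(=O)c3c(o2)C(CC)(CC)C(=O)C(CC)=C3O)cc1`) gives 12.2 uM and compound 2 (`CCC1=C(O)c2c(oc(-c3ccc(SC)cc3)cc2=O)C(CC)(CC)C1=O`) gives 1.38 uM while compound 3 (`CCC1=C(O)c2c(oc(-c3ccc(COC)cc3)cc2=O)C(CC)(CC)C1=O`) gives 3.4 uM and so holds the second highest of the three numbers. The unmeasured compound 4 (`CCC1=C(O)c2c(oc(-c3ccccc3OC)cc2=O)C(CC)(CC)C1=O`) keeps the shared core but carries 2-methoxyphenyl in place of 4-(methoxymethyl)phenyl on an aromatic carbon.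

Among the measured compounds shown here, three measured steps bear on this change, since each alters the substituent on the same aromatic ring. Methylsulfanyl in place of propyl gives an 8.8-fold lower number from compound 1 to compound 2 (0.95 log units; beyond the scatter) and methoxy in place of ethyl on the saturated chain gives a 3.6-fold lower number from compound 1 to compound 3 (0.55 log units; beyond the scatter) while methoxymethyl in place of methylsulfanyl gives a 2.5-fold higher number from compound 2 to compound 3 (0.39 log units; beyond the scatter) within the same series. These steps run in both directions and all are modest. None of the three measured compounds carries a 2-methoxyphenyl group, so the data offer no direct measure of this replacement. A modest move at most is therefore expected, leaning slightly upward, and the estimated change is a 1.5-fold higher number from compound 3 to compound 4 (0.17 log units; within the scatter) for this replacement. Compound 4 is expected at 5 uM (estimated range 1.6 uM to 15 uM).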

Compound 4, concentration for half-maximal effect: 3.26 uM
Compound 4: middle estimate off by 1.5-fold (0.19 log units), on the high side, and the stated range covers the measured number.
By their numbers in this assay, from the lowest: compound 2; then compounds 4 and 3 (each within the scatter of the next); then compound 1.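

In this assay, among the compounds shown here, 2-methoxyphenyl in place of 4-(methoxymethyl)phenyl gives a 1.0-fold lower number from compound 3 to compound 4 (0.02 log units; within the scatter), so on this aromatic carbon next to the ring oxygen the two groups cannot be told apart, a level result that the earlier compounds could not show. The same group gives a 2.4-fold higher number from compound 2 to compound 4 (0.37 log units; beyond the scatter) and a 3.7-fold lower number from compound 1 to compound 4 (0.57 log units; beyond the scatter), so compound 4, like compound 3, lies between the 4-(methylsulfanyl)phenyl of compound 2 and the 4-propylphenyl of compound 1, and both oxygen-bearing groups shown now fall in that middle stretch. No measurement at hand accounts for these numbers.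

Compound 4 differs from compound 3 both in the group itself and in where that group sits on the phenyl ring, and the compounds shown do not separate these two changes, so a level result here may hide opposing contributions or none at all. Also open, as far as these compounds go, is how a plain unsubstituted phenyl, or a phenyl ring carrying an amine or a carboxylic acid, would stand against these four compounds at this position.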